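The compounds below may be only part of what the source reports. "The series", "measured", "known", "first", "only" and "open" are said of these compounds alone.

Compound 3 `COc1cc2ncnc(Nc3ccc(F)c(Cl)c3)c2cc1NC(=O)N/N=C/c1ccc(F)cc1` gives 36500 nM in a functional assay on PC-3 cells (Homo sapiens) for cytotoxicity, read by MTT assay, with a stated time of 72 h (a higher number here means a weaker inhibitor, a lower number a stronger inhibitor), the highest of the three numbers recorded. Compound 1 `COc1ccc(/C=N/NC(=O)Nc2cc3c(Nc4ccc(F)c(Cl)c4)ncnc3cc2O[C@H]2CCOC2)c(OC)c1OC` stands nearest to it with 25600 nM, a gap within the scatter, while compound 2 `O=C(N/N=C/c1cc(Br)c(O)c(Br)c1)Nc1cc2c(Nc3ccc(F)c(Cl)c3)ncnc2cc1O[C@H]1CCOC1` lies furthest with 6160 nM, a gap beyond it. Among the measured compounds shown here, the one step measured between two compounds that differ in a single place, a 4.2-fold lower number from compound 1 to compound 2 (0.62 log units; beyond the scatter), put a 3,5-dibromo-4-hydroxyphenyl in place of a 2,3,4-trimethoxyphenyl on the carbon with a double bond to nitrogen.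

Compound 4 `COc1cc2ncnc(Nc3ccc(F)c(Cl)c3)c2cc1NC(=O)N/N=C/c1ccc(O)cc1` differs from compound 3 in one place: hydroxy in place of fluoro on an aromatic carbon. Read one bond further out, this is 4-fluorophenyl to 4-hydroxyphenyl. The change from compound 1 to compound 2 bears on this only loosely: a hydroxy entered there too, but together with two bromines, and in place of three methoxy groups rather than a single fluoro. For the measured compounds named here, no measured pair shows a hydroxy exchanged for a fluoro alone. The step is therefore expected in this assay to be modest at most, toward a lower number if anything, and it may well stay within the scatter; a 1.5-fold lower number from compound 3 to compound 4 (0.16 log units; within the scatter) is the estimate. Compound 4 is expected to give about 25000 nM in this assay, with a range from 8000 nM to 80000 nM.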

Compound 4, half-maximal inhibitory concentration: 16600 nM
For compound 4 the middle estimate is 1.5-fold (0.18 log units) above the measured one, within the range that was stated.
By their numbers in this assay, from the lowest: compound 2; then compounds 4, 1 and 3 (each within the scatter of the next, the first and the last beyond it).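

The step of a 2.2-fold lower number from compound 3 to compound 4 (0.34 log units; beyond the scatter) in this assay isolates a single exchange, hydroxy in place of fluoro on an aromatic carbon para to a large group, and although modest, it lies beyond the scatter. The earlier step, a 4.2-fold lower number from compound 1 to compound 2 (0.62 log units; beyond the scatter), could not show this, since its hydroxy entered together with two bromines and three methoxy groups left. Here, with the rest of compound 3 and compound 4 the same, one heavy atom replaces another and the count rises by one hydrogen-bond donor and one hydrogen-bond acceptor, but nothing measured here explains why the number falls with this exchange.

The compounds shown leave open how an amine or a carboxylic acid at this same place on the ring would compare with hydroxy and fluoro in this assay. They also leave open whether hydroxy in place of fluoro would give a similar step on the core of compound 1, and whether adding bromines to the 4-hydroxyphenyl of compound 4 would lower the number further.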